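Adding a Methoxy Group: From Compound 2 to Compound 3

The source may report more compounds than this note shows. Statements on the series, on what has been measured and on what is new or still open speak of the compounds shown alone.

Compound 2 `COc1ccc(C(=O)c2cc(OC)c(OC)c(OC)c2)cc1NC(=O)/C=C/c1ccc(C(F)(F)F)cc1` in a functional assay on HT-29 cells (Homo sapiens) for cytotoxicity, read by MTT assay, with a stated time of 72 h (a higher number here means a weaker inhibitor, a lower number a stronger inhibitor), gives 1600 nM. Among the measured compounds shown here, compound 1 `COc1ccc(C(=O)c2cc(OC)c(OC)c(OC)c2)cc1NC(=O)/C=C/c1ccc(F)cc1` gives 1800 nM in this assay, so the two numbers lie within the scatter of each other, the only measured step being a 1.1-fold lower number from compound 1 to compound 2 (0.05 log units; within the scatter). Compound 3 `COc1cc(C(=O)c2cc(OC)c(OC)c(OC)c2)cc(NC(=O)/C=C/c2ccc(C(F)(F)F)cc2)c1OC` differs from compound 2 by methoxy in place of hydrogen on an aromatic carbon. That measured step changed a group on a different ring and stayed within the scatter, so nothing measured bears directly on adding a methoxy here. No step beyond the scatter is therefore expected, and compound 3 is estimated at 2000 nM, within 700 nM to 6000 nM, meaning an expected step of a 1.3-fold higher number from compound 2 to compound 3 (0.10 log units; within the scatter).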

Compound 3, half-maximal inhibitory concentration: 1900 nM
Compound 3: middle estimate off by 1.1-fold (0.02 log units), on the high side; measured number inside the range.
By their numbers in this assay, from the lowest: compounds 2, 1 and 3 (each within the scatter of the next).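

In this assay, among the compounds shown here, methoxy in place of hydrogen on this aromatic carbon, ortho to a methoxy group, gives a 1.2-fold higher number from compound 2 to compound 3 (0.07 log units; within the scatter) and is the only measured step on this ring. This carbon therefore carries an added methoxy with no step beyond the scatter, whereas the earlier step concerned a different ring. No measured evidence accounts for this result.

Going by these compounds, whether an amine, a hydroxyl or a longer ether chain on this carbon would behave the same stays open. So does whether methoxy here would read alike with fluoro in place of trifluoromethyl.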